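Replacing fluoro with ethoxycarbonyl in compound 3

This account rests on a few compounds, and the source may have more. Where it says the series, first, only, none or still open, it means among the compounds named here.

Going by the values given here, in an ADME assay on MDBK cells (Bos taurus) for cytotoxicity, read by MTT assay, with a stated time of 96 h (a lower number here means that less compound is tolerated, a higher number that more compound is tolerated), compound 3 `Fc1ccc(NC(=S)Nc2cccc(C(F)(F)F)c2)cc1` gives 41000 nM, the highest of the three numbers known so far. Compound 1 `CC[C@H]1CC[C@H](c2ccc(NC(=S)Nc3cccc(C(F)(F)F)c3)cc2)CC1` gives 9000 nM and compound 2 `CCCC[C@H]1CC[C@H](c2ccc(NC(=S)Nc3cccc(C(F)(F)F)c3)cc2)CC1` gives 10000 nM, which is only a 1.1-fold higher number from compound 1 to compound 2 (0.05 log units; within the scatter). Compound 4 `CCOC(=O)c1ccc(NC(=S)Nc2cccc(C(F)(F)F)c2)cc1` has ethoxycarbonyl in place of fluoro on an aromatic carbon. Fluoro in place of 4-ethylcyclohexyl gave a 4.6-fold higher number from compound 1 to compound 3 (0.66 log units; beyond the scatter), and fluoro in place of 4-butylcyclohexyl gave a 4.1-fold higher number from compound 2 to compound 3 (0.61 log units; beyond the scatter). Among the compounds with values here, no measured compound carries ethoxycarbonyl, so these two steps are the only guide, and they suggest that a group other than fluoro may lower the number. A somewhat smaller step is expected here: a 2.1-fold lower number from compound 3 to compound 4 (0.31 log units; beyond the scatter). The estimate for compound 4 is 20000 nM, with an expected range of 8000 nM to 45000 nM.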

Compound 4, half-maximal cytotoxic concentration: 64000 nM
Compound 4: middle estimate off by 3.2-fold (0.51 log units), on the low side, and the stated range ends below it.
By their numbers in this assay, from the lowest: compounds 1 and 2 (each within the scatter of the next); then compounds 3 and 4 (each within the scatter of the next).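

In this assay, ethoxycarbonyl, with its 5 heavy atoms, is tolerated at this position about as well as fluoro, with a 1.6-fold higher number from compound 3 to compound 4 (0.19 log units; within the scatter). The gap to the cyclohexyl compounds also remains for this second group, with a 6.4-fold higher number from compound 2 to compound 4 (0.81 log units; beyond the scatter) and a 7.1-fold higher number from compound 1 to compound 4 (0.85 log units; beyond the scatter), so replacing fluoro does not by itself lower the number. Nothing available explains this result.

As far as these compounds go, it remains open whether an amine, a carboxylic acid or a simple longer chain here would stay level with fluoro and ethoxycarbonyl or fall towards the 4-ethylcyclohexyl and 4-butylcyclohexyl compounds.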